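The compounds below may be only part of what the source reports. "The series", "measured", "known", "first", "only" and "open" are said of these compounds alone.

Working notes on the series in a functional assay on a cell-free system (plasma, Oryctolagus cuniculus) for inhibition of platelet-activating factor acetylhydrolase (Homo sapiens), tested at 100 nM; on this read-out lower numbers stand for less inhibition and higher numbers for more inhibition at the one concentration tested (going by the name of the read-out). Compound 1 `CCCCCCCCN(C)C(=O)Cn1cc(Cc2cnc(=O)n(C)c2)c(=O)nc1SCc1ccc(F)cc1` gives 19%. Compound 2 `CCCCCCCCN(C)C(=O)Cn1cc(Cc2cnc(=O)n(CCO)c2)c(=O)nc1SCc1ccc(F)cc1` gives 36%, and compound 3 `CCCCCCCCN(C)C(=O)Cn1cc(Cc2cnc(=O)n(CC(=O)NC)c2)c(=O)nc1SCc1ccc(F)cc1` gives 42%. Compound 3 thus holds the highest of the three numbers; its gap to compound 2 lies within the scatter, so no order between these two can be read, while its gap to compound 1 lies beyond it.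

All measured steps touch the same saturated chain carbon bound to an aromatic nitrogen: a number 17 percentage points higher from compound 1 to compound 2 (beyond the scatter); a number 23 percentage points higher from compound 1 to compound 3 (beyond the scatter); a number 6 percentage points higher from compound 2 to compound 3 (within the scatter). Each group entering in place of hydrogen brought a modest rise; exchanging hydroxymethyl for methylcarbamoyl brought nothing beyond the scatter.

Compound 4 `CCCCCCCCN(C)C(=O)Cn1cc(Cc2cnc(=O)n(CC(=O)NCCO)c2)c(=O)nc1SCc1ccc(F)cc1` carries the change one bond further out than compound 3: hydroxymethyl in place of hydrogen on a saturated chain carbon bound to an amide-type nitrogen. Among the compounds with values here, no measured step sits at a carbon bound to an amide-type nitrogen, and the only comparison between a hydroxymethyl-bearing and a methylcarbamoyl-bearing compound was within the scatter. The step in this assay is therefore expected to be small, with no clear direction, a slight rise being as likely as none.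

For compound 4 the expected value is 45%, ranging from 30% to 60%.

That corresponds to an expected step of a number 3 percentage points higher from compound 3 to compound 4 (within the scatter) for compound 4.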

Compound 4, a percentage reported as inhibition, at one concentration (the size of the read-out at that concentration, not a potency): 40%
Beside the measured number, compound 4's estimate is 5 percentage points above it; the range from low to high includes it.
By their numbers in this assay, from the lowest: compound 1; then compounds 2, 4 and 3 (each within the scatter of the next).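

In this assay, hydroxymethyl in place of hydrogen on a saturated chain carbon bound to an amide-type nitrogen gives a number 2 percentage points lower from compound 3 to compound 4 (within the scatter), and the comparison with the shorter hydroxyl-bearing group gives a number 4 percentage points higher from compound 2 to compound 4 (within the scatter), so the (2-hydroxyethyl)carbamoyl group cannot be told apart from either earlier group. The comparison with the smallest group gives a number 21 percentage points higher from compound 1 to compound 4 (beyond the scatter), so all three larger groups on the saturated chain carbon bound to an aromatic nitrogen now stand clear of compound 1, and the added length and hydroxyl of compound 4 bring no further gain that can be read. The same hydroxymethyl-for-hydrogen change therefore does not carry a fixed effect from one place to the other: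
the same change on two cores in this assay, a number 17 percentage points higher (beyond the scatter) from compound 1 to compound 2 and a number 2 percentage points lower (within the scatter) from compound 3 to compound 4, 19 percentage points apart, beyond the scatter of two such steps

Going by these compounds, it remains open whether an amine or a carboxylic acid at the end of this chain, or a longer chain, would lift the number clear of compounds 2, 3 and 4. On these data alone, with a single tested concentration, any difference in potency among those three also remains open.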